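The compounds below may be only part of what the source reports. "The series", "measured", "known", "first", "only" and "open" are said of these compounds alone.

Among the compounds with a number in a functional assay on LNCaP C4-2 cells (Homo sapiens) for inhibition, read by MTT assay, with a stated time of 48 h (on this read-out higher numbers stand for weaker inhibition and lower numbers for stronger inhibition), compound 1 `Clc1ccc(Cn2cc(C3CC(c4ccncc4)=NO3)c3ccccc32)cc1` gives 11400 nM, the highest of the two numbers. Compound 3 `Cc1c(C2CC(c3ccncc3)=NO2)c2ccccc2n1Cc1ccc(Cl)cc1` gives 2500 nM, so the step of a 4.6-fold lower number from compound 1 to compound 3 (0.66 log units; beyond the scatter), a methyl in place of hydrogen on an aromatic carbon, strengthened inhibition. Compound 2 `COc1ccc2c(c1)c(C1CC(c3ccncc3)=NO1)cn2Cc1ccc(Cl)cc1` reaches only the limit of the assay, > 100000 nM. Since compound 2 sits at the limit of > 100000 nM in this assay, at which 1 of the 3 values shown sits, the step of an at least 8.7-fold higher number from compound 1 to compound 2 (0.94 log units; beyond the scatter) is known only as a bound. Compound 4 `COc1ccc2c(C3CC(c4ccncc4)=NO3)cn(Cc3ccc(Cl)cc3)c2c1` differs from compound 1 by methoxy in place of hydrogen on an aromatic carbon; this is the same group that entered in compound 2, though on another aromatic carbon of the core. On that likeness, weaker inhibition is expected for compound 4, a step of a 3.5-fold higher number from compound 1 to compound 4 (0.55 log units; beyond the scatter), with an estimate of 40000 nM, between 10000 nM and 150000 nM, and a real chance that the assay again reports only a limit.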

Compound 4, half-maximal inhibitory concentration: > 100000 nM
Compound 4: only a limit was reported (the forecaster's own chance of this, stated with the estimate: 30%); middle value at least 2.5-fold (0.39 log units) from the limit.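

Methoxy in place of hydrogen on this aromatic carbon, meta to a fused ring and para to a fused ring, gives an at least 8.7-fold higher number from compound 1 to compound 4 (0.94 log units; beyond the scatter) and that size is only a bound, as the value of compound 4 is a limit. Weaker inhibition with methoxy is therefore not tied to one carbon of the core, since compound 2 and compound 4 carry it on different carbons. These two cannot be ranked, as both stop at the same limit: the limit of > 100000 nM in this assay, at which 2 of the 4 values shown sit.

As far as these compounds go, whether fluorine or an amine would be tolerated on these carbons stays open. So does whether methyl, which strengthened inhibition on another aromatic carbon in compound 3, would do the same here.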